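Three Amides and a Trifluoromethoxy Follow-Up

A few compounds are considered here, and "the series" means these few. Any claim that something is new, unique, unknown or untested is made for them only; others in the source may bear on it.

Compound 1: `Cc1ccc2nc(C(=O)Nc3c(F)cc(-c4cccc(F)c4)cc3F)c(C)c(O)c2c1` — 3.04%
Compound 2: `Cc1c(C(=O)Nc2c(F)cc(-c3cccc(F)c3)cc2F)nc2ccc(F)cc2c1O` — 2.34%
Compound 3: `CCOc1ccc2nc(C(=O)Nc3c(F)cc(-c4cccc(F)c4)cc3F)c(C)c(O)c2c1` — 2.96%

All three compounds were tested in a functional assay on A-375 cells (Homo sapiens) for antiproliferative activity, read by MTT assay, with a stated time of 24 h, tested at 1.23 ug/mL (a lower number here means a weaker effect, a higher number a stronger effect of the compound at the concentration tested), and gave numbers close to one another. Compound 3 stands second highest of the three, with compound 1 nearest (a number 0.1 percentage points lower from compound 1 to compound 3 (within the scatter)) and compound 2 furthest (a number 0.6 percentage points higher from compound 2 to compound 3 (within the scatter)); the step of a number 0.7 percentage points lower from compound 1 to compound 2 (within the scatter) is likewise within the scatter, so none of the three can be told apart on these numbers.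

Compound 4, `Cc1c(C(=O)Nc2c(F)cc(-c3cccc(F)c3)cc2F)nc2ccc(OC(F)(F)F)cc2c1O`, differs from compound 3 in one place: trifluoromethyl in place of ethyl on an oxygen on an aromatic ring. Within the data shown here, no measured step touches this oxygen; the closest guide is that every change at this aromatic carbon so far, methyl, fluoro or ethoxy, left the read-out unchanged within the scatter. It is therefore expected that compound 4 also shows no step beyond the scatter, a number 0 percentage points higher from compound 3 to compound 4 (within the scatter). Compound 4 is estimated at 3%, with a range from 0% to 12%.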

Compound 4, a percentage reported as inhibition, at one concentration (the size of the read-out at that concentration, not a potency): 1.57%
Beside the measured number, compound 4's estimate is 1.4 percentage points above it; measured number inside the range.
By their numbers in this assay, from the lowest: compounds 4, 2, 3 and 1 (each within the scatter of the next).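

In this assay, trifluoromethyl in place of ethyl on the oxygen gives a number 1.4 percentage points lower from compound 3 to compound 4 (within the scatter), so a fluorinated ether at this aromatic carbon is no more distinguishable than the ethoxy group. The comparisons with the other two groups at this carbon read the same way: trifluoromethoxy in place of fluoro gives a number 0.8 percentage points lower from compound 2 to compound 4 (within the scatter), and trifluoromethoxy in place of methyl gives a number 1.5 percentage points lower from compound 1 to compound 4 (within the scatter). Nothing further in the data bears on this result.

The compounds shown leave open whether a group such as an amine, a carboxylic acid or a longer alkoxy chain at this aromatic carbon would give a step beyond the scatter. They also leave open whether these four compounds would separate at a higher concentration.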